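Amide alkyl variation on the shared core

The compounds below may be only part of what the source reports. "The series", "measured", "known", "first", "only" and "open" are said of these compounds alone.

Compound 1 `CCC1C(=O)N(C)c2cnc(-n3ccc4cc(C(=O)NCC(C)C)ccc43)nc2N1c1ccn(C)n1` gives 4810 nM in a functional assay on MCF7 cells (Homo sapiens) for antiproliferative activity, read by CCK-8 assay, with a stated time of 72 h; on this read-out lower numbers stand for stronger inhibition of growth and higher numbers for weaker inhibition of growth. For the measured compounds named here, compound 2 `CCC1C(=O)N(C)c2cnc(-n3ccc4cc(C(=O)NC(C)C)ccc43)nc2N1c1ccn(C)n1` gives 8420 nM in this assay, and the step of a 1.8-fold higher number from compound 1 to compound 2 (0.24 log units; within the scatter) is the only single-point change measured so far. Going by the values given here, compound 3 `CC[C@@H]1C(=O)N(C)c2cnc(-n3ccc4cc(C(=O)NC5CCCC5)ccc43)nc2N1C1CCCC1`, which differs from both at several places, gives 795 nM in this assay; its number sits well below that of compound 2, beyond the scatter, but no single step connects the two. On the numbers shown, compound 2 carries the highest value of the three, with compound 1 nearest to it and compound 3 furthest away.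

Compound 4 `CCCNC(=O)c1ccc2c(ccn2-c2ncc3c(n2)N(c2ccn(C)n2)C(CC)C(=O)N3C)c1` is the next point on the amide chain: propyl in place of isopropyl on an amide-type nitrogen. Among the compounds with values here, the one measured step that bears on this place, from compound 1 to compound 2, exchanged one short alkyl for another and stayed within the scatter. A second exchange of the same kind is therefore expected to give no step beyond the scatter in this assay in either direction. For compound 4 the expected value is 6500 nM, with a range from 2500 nM to 17000 nM. The step this implies, a 1.3-fold lower number from compound 2 to compound 4 (0.11 log units; within the scatter), is expected to remain within the scatter.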

Compound 4, concentration for 50% growth inhibition: 6420 nM
Estimate against measurement, compound 4: 1.0-fold (0.01 log units) above, and the stated range covers the measured number.
By their numbers in this assay, from the lowest: compound 3; then compounds 1, 4 and 2 (each within the scatter of the next).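

Isopropyl and propyl on the amide-type nitrogen carry the same heavy-atom count joined differently, and in this assay that exchange gives a 1.3-fold lower number from compound 2 to compound 4 (0.12 log units; within the scatter), so this rearrangement of the alkyl group does not separate the two compounds. The second new pair isolates a different edit on the same chain, hydrogen in place of methyl on a saturated chain carbon bound to two saturated chain carbons, and it gives a 1.3-fold higher number from compound 1 to compound 4 (0.13 log units; within the scatter), so isobutyl and propyl are not separated either. Together with a 1.8-fold higher number from compound 1 to compound 2 (0.24 log units; within the scatter), all three pairs among compound 1, compound 2 and compound 4 now lie within the scatter, none of the three goes against this flat reading, and no measurement shown bears on why these groups read alike.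

Compound 3 gives 795 nM but differs from these compounds in more than one place, so the share of its cyclopentyl amide in that number remains unassigned. Still open, as far as these compounds go, is whether a longer chain such as hexyl, or a chain ending in an amine or a carboxylic acid, on the amide-type nitrogen would give a step beyond the scatter.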